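A few compounds are considered here, and "the series" means these few. Any claim that something is new, unique, unknown or untested is made for them only; others in the source may bear on it.

Working notes on the series. Among the measured compounds shown here, in a functional assay on MCF7 cells (Homo sapiens) for cytotoxicity, read by colorimetric assay and MTT assay (on this read-out higher numbers stand for weaker inhibition and lower numbers for stronger inhibition), compound 1 (`CCOC(=O)Cn1c(=O)c(-c2ccc(OC)cc2)cc2c(OC)cc(OC)cc21`) gives 10000 nM and compound 2 (`COc1ccc(-c2cc3c(OC)cc(OC)cc3n(CCCC#N)c2=O)cc1`) gives 10000 nM, so compound 2 stands level with compound 1, its only measured neighbour. The next structure is compound 3 (`COc1ccc(-c2cc3c(OC)cc(OC)cc3n(CC(=O)OCc3ccccc3)c2=O)cc1`). The change is benzyloxycarbonyl in place of 2-cyanoethyl on a saturated chain carbon bound to an aromatic nitrogen.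

For the measured compounds named here, one measured step bears on this: no change at the digits printed from compound 1 to compound 2 (within the scatter). It concerns the same place, exchanges ethoxycarbonyl for 2-cyanoethyl and stays within the scatter. Going by the values given here, that is thin evidence, since it is a single step and no measured compound has an added aromatic ring at this place. Among the compounds with values here, with that flat step as the only guide, no shift beyond the scatter is expected in this assay, and the direction remains open. The expected step is a 1.1-fold lower number from compound 2 to compound 3 (0.05 log units; within the scatter). For compound 3 the estimated value is 9000 nM, with an expected range from 3500 nM to 20000 nM.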

Compound 3, half-maximal inhibitory concentration: 10000 nM
Estimate against measurement, compound 3: 1.1-fold (0.05 log units) below; the range from low to high includes it.
By their numbers in this assay, from the lowest: compounds 1, 2 and 3 (each within the scatter of the next).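

In this assay, this place now has a measured result for a group carrying an aromatic ring: with benzyloxycarbonyl in place of 2-cyanoethyl on a saturated chain carbon bound to an aromatic nitrogen, the step reads no change at the digits printed from compound 2 to compound 3 (within the scatter). The ester end of the same substituent gives the same reading with phenyl in place of methyl on a saturated chain carbon bound to an oxygen next to a carbonyl group, no change at the digits printed from compound 1 to compound 3 (within the scatter), so the flat picture now covers 2-cyanoethyl and both esters, including the one with the six-membered aromatic ring. No supporting data are available to account for this flat reading.

Still open is whether an amine, a carboxylic acid or a longer chain at this place would give a step beyond the scatter, as all steps among these three compounds stay within it. Also open, going by these compounds, is whether a hydroxyl group in place of a methoxy group on the shared core would move the read-out, as compounds 1, 2 and 3 all carry that core unchanged.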